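Swapping the dichlorophenoxy group for a fluorophenoxy group

A few compounds are considered here, and "the series" means these few. Any claim that something is new, unique, unknown or untested is made for them only; others in the source may bear on it.

Measured so far:
Compound 1 `Nc1cc(N)c2nc(-c3ccccc3)c(Oc3ccc(Cl)c(Cl)c3)nc2c1`; in a functional assay on UO-31 cells (Homo sapiens) for inhibition, read by sulforhodamine B assay, with a stated time of 48 h (a lower number here means a stronger inhibitor of growth, a higher number a weaker inhibitor of growth), compound 1 gives < 100000 nM, which is a limit of the assay and not a number.
Compound 2 `CCOC(=O)[C@H](CCC(=O)O)NC(=O)c1ccc(CNc2nc3cc(N)cc(N)c3nc2-c2ccccc2)cc1`; in this assay compound 2 gives < 100000 nM, likewise a limit.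

Compound 1 therefore has no exact number in this assay: its value is only a limit, and the same holds for the other compound shown, so both sit at the limit of < 100000 nM in this assay, at which 2 of the 2 values shown sit. Going by the values given here, no pair of measured compounds differs in a single place, so no measured step is available to guide a prediction. Compound 3 `Nc1cc(N)c2nc(-c3ccccc3)c(Oc3ccc(F)cc3)nc2c1` is the next compound. It differs from compound 1 by 4-fluorophenyl in place of 3,4-dichlorophenyl on an oxygen on an aromatic ring. With nothing measured to lean on, the change is expected to stay within the usual scatter, and a step that the limit leaves unreadable from compound 1 to compound 3 is the estimated step. For compound 3 the concentration for total growth inhibition is expected near 50000 nM, within a range from 10000 nM to 100000 nM.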

Compound 3, concentration for total growth inhibition: 45700 nM
Estimate against measurement, compound 3: 1.1-fold (0.04 log units) above, and the stated range covers the measured number.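

No step can be read between compound 1 and compound 3, because in this assay compound 1 gives only a limit and not a number: the limit of < 100000 nM in this assay, at which 2 of the 3 values shown sit. The compounds shown leave open whether 4-fluorophenyl or 3,4-dichlorophenyl on this oxygen gives the stronger inhibitor of growth.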